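From thiophen-2-yl to ethynyl on the shared core

The compounds below may be only part of what the source reports. "The series", "measured", "known", "first", "only" and "open" are said of these compounds alone.

In a functional assay on HeLa S3 cells (Homo sapiens) for antiproliferative activity, read by XTT assay, with a stated time of 72 h (a higher number here means a weaker inhibitor, a lower number a stronger inhibitor), compound 3 (`CNc1ncnc2c1c(-c1cccs1)cn2[C@@H]1O[C@H](CO)[C@@H](O)[C@H]1O`) gives > 20000 nM, which is a limit and not a number. It therefore stands at the limit of > 20000 nM in this assay, at which 1 of the 3 values shown sits. Where compound 3 carries thiophen-2-yl, compound 2 (`CNc1ncnc2c1c(-c1ccco1)cn2[C@@H]1O[C@H](CO)[C@@H](O)[C@H]1O`) carries furan-2-yl and gives 5000 nM. Compound 1 (`C#Cc1cn([C@@H]2O[C@H](CO)[C@@H](O)[C@H]2O)c2ncnc(OC)c12`) already carries ethynyl, although it differs elsewhere from the compound considered next, and gives 1730 nM.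

The change now followed leads to compound 4 (`C#Cc1cn([C@@H]2O[C@H](CO)[C@@H](O)[C@H]2O)c2ncnc(NC)c12`), with ethynyl in place of thiophen-2-yl on an aromatic carbon. Among the compounds with values here, the one measured step at this carbon is an at least 4.0-fold higher number from compound 2 to compound 3 (0.60 log units; beyond the scatter). It shows that this assay responds to a change of group at this place, but it does not involve ethynyl. The closest guide to ethynyl is therefore compound 1 at 1730 nM, while compound 2 at 5000 nM supports a number well inside the measurable range. Together these two values lead to the expectation of a lower number, a stronger inhibitor, beyond the scatter. The expected size of the change is an at least 11-fold lower number from compound 3 to compound 4 (1.04 log units; beyond the scatter), and it remains only an estimate. For compound 4 the estimated value is 1800 nM, with an expected range from 300 nM to 10000 nM.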

Compound 4, half-maximal inhibitory concentration: > 20000 nM
Compound 4 was reported as a limit (the forecaster's own chance of this, stated with the estimate: 12%); at least 11-fold (1.04 log units) between middle value and limit.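

In this assay, ethynyl on this carbon does not secure a measurable number on its own: with methylamino kept on the shared core, ethynyl in place of furan-2-yl gives an at least 4.0-fold higher number from compound 2 to compound 4 (0.60 log units; beyond the scatter). With ethynyl kept instead, methylamino in place of methoxy on an aromatic carbon gives an at least 11-fold higher number from compound 1 to compound 4 (1.06 log units; beyond the scatter), the first step shown for a change at that second place, and it means that the number of compound 1 does not carry over to a compound with methylamino. Compound 4 is reported only as a limit and, with compound 3 also a limit, the step between the two cannot be read: the limit of > 20000 nM in this assay, at which 2 of the 4 values shown sit.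

Among the compounds with methylamino, only furan-2-yl gives a number inside the measurable range, so the order of ethynyl and thiophen-2-yl stays open, and so does whether furan-2-yl is helped by methoxy as ethynyl is. Going by these compounds, it also stays open what a plain amine or an ethylamino chain would give in place of methylamino with ethynyl kept, and whether a nitrile or a phenyl group on this carbon would bring the number back into the measurable range.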